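This account rests on a few compounds, and the source may have more. Where it says the series, first, only, none or still open, it means among the compounds named here.

Compound 2 `Nc1nc(O)c2ncn([C@H]3CCC[C@H]3CO)c2n1` carries a hydroxy group on the shared core. In a functional assay on MOLT-4 cells (Homo sapiens) for antiproliferative activity (a higher number here means a weaker inhibitor, a lower number a stronger inhibitor), compound 2 gives > 200000 nM, which is a limit of the assay and not a number, so compound 2 stands only as the weakest end of what the data show: the limit of > 200000 nM in this assay, at which 1 of the 3 values shown sits. Compound 1 `Nc1nc(Cl)c2ncn([C@H]3CCC[C@H]3CO)c2n1`, with chloro at the same position, gives 49100 nM in this assay, and the step of an at least 4.0-fold higher number from compound 1 to compound 2 (0.60 log units; beyond the scatter) marks the change of hydroxy in place of chloro as costly. Compound 3 `Nc1nc(O)c2nnn([C@H]3CCC[C@H]3CO)c2n1`, on a different core but with the same hydroxy group, gives 86000 nM in this assay.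

Compound 4 `Nc1nc(N)c2ncn([C@H]3CCC[C@H]3CO)c2n1` differs from compound 2 by amino in place of hydroxy on an aromatic carbon. Within the data shown here, no measured step covers this exchange; the only step available, from compound 1 to compound 2, concerns chloro and hydroxy, and it only shows that the hydroxy compound 2 is the weakest of the three. With amino rather than hydroxy, compound 4 is expected to recover activity toward the level of compound 1, estimated as an at least 3.3-fold lower number from compound 2 to compound 4 (0.52 log units; beyond the scatter). Compound 4 is thus expected to give about 60000 nM in this assay, with a range from 15000 nM to 200000 nM, and a fair chance that only a limit is reported.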

Compound 4, half-maximal inhibitory concentration: 147000 nM
Compound 4: middle estimate off by 2.5-fold (0.39 log units), on the low side; low and high end bracket the measured number.
By their numbers in this assay, from the lowest: compounds 1, 3 and 4 (each within the scatter of the next, the first and the last beyond it). At a limit, above all of these: compound 2.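

In this assay the amino group, on an aromatic carbon next to the ring nitrogen, does not match chloro: amino in place of chloro gives a 3.0-fold higher number from compound 1 to compound 4 (0.48 log units; beyond the scatter) and so the cost of leaving chloro, seen until now only with hydroxy, also appears with a second group. Amino in place of hydroxy gives an at least 1.3-fold lower number from compound 2 to compound 4 (0.13 log units; that floor lies within the scatter) and since that floor lies within the scatter, these values do not establish a real gain from amino over hydroxy. Compound 2 still stands only at a limit of the assay, not at a number: the limit of > 200000 nM in this assay, at which 1 of the 4 values shown sits.

The compounds shown leave open whether any other group at this position, such as bromo, fluoro, methoxy, a thiol or a methylamino group, would equal or better chloro, so chloro's lead is established only against hydroxy and amino on this core. They also leave open whether the same order holds on the core of compound 3, where hydroxy is the only group shown, and whether chloro or amino would behave there as they do on the shared core.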